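Aryl for alkyl swap on the shared core: compound 3

A few compounds are considered here, and "the series" means these few. Any claim that something is new, unique, unknown or untested is made for them only; others in the source may bear on it.

Measured compounds:
compound 1 `CC(C)n1nc(-c2cc(-c3ccccc3)on2)c2c(N)ncnc21`, 3460 nM
compound 2 `CC(C)c1cc(-c2nn(C(C)C)c3ncnc(N)c23)no1`, 2400 nM

Both measured compounds were run in an assay on BaF3 cells for inhibition of proto-oncogene tyrosine-protein kinase receptor Ret (Homo sapiens), read by MTT assay, with a stated time of 48 h; a lower number here means a stronger inhibitor of growth, a higher number a weaker inhibitor of growth. Compound 1 gives 3460 nM and compound 2 gives 2400 nM. For the measured compounds named here, the single step between them, a 1.4-fold lower number from compound 1 to compound 2 (0.16 log units; within the scatter), stays within the scatter, so neither compound can be ranked against the other. Going by the values given here, compound 2 carries the lower of the two numbers, with compound 1 its only neighbour.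

Compound 3 `CC(C)n1nc(-c2cc(-c3ccc(F)cc3)on2)c2c(N)ncnc21` is the next compound in line. Its change from compound 2 is 4-fluorophenyl in place of isopropyl on an aromatic carbon. Among the compounds with values here, the only measured step that bears on it is the one from compound 1 to compound 2, which put isopropyl in place of phenyl on the same aromatic carbon and stayed within the scatter. Compound 3 reverses that exchange and brings a fluorine on the ring, so the aryl-bearing compound 1 is the closest measured reference. No step beyond the scatter is therefore expected in this assay; the expected step is a 1.3-fold higher number from compound 2 to compound 3 (0.10 log units; within the scatter), which would place compound 3 near compound 1. For compound 3 the estimate is 3000 nM with a range of 1200 nM to 8000 nM.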

Compound 3, concentration for 50% growth inhibition: > 10000 nM
Compound 3 was reported as a limit; the forecaster's own chance of this, stated with the estimate: 5%; at least 3.3-fold (0.52 log units) between middle value and limit.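

Compound 3 stands at a limit of the read-out in this assay, not at a number: the limit of > 10000 nM in this assay, at which 1 of the 3 values shown sits. For the compounds shown here, in the one earlier comparison at this aromatic carbon next to the ring oxygen, the exchange of phenyl for isopropyl gave a 1.4-fold lower number from compound 1 to compound 2 (0.16 log units; within the scatter), so the position looked insensitive to that change, whereas the 4-fluorophenyl group now gives an at least 4.1-fold higher number from compound 2 to compound 3 (0.61 log units; beyond the scatter). The smaller edit shows the same thing more sharply: fluoro in place of hydrogen on an aromatic carbon of the phenyl group alone gives an at least 2.8-fold higher number from compound 1 to compound 3 (0.46 log units; beyond the scatter), so growth inhibition at this position depends on more than the choice between aryl and alkyl, and a single atom on the aryl group is enough to separate two compounds.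

On these data alone, the true size of both new steps remains unknown, and one fluorine on one ring carbon cannot show whether any other group at that place would act the same way. Open, as far as these compounds go, is whether a methoxy group, an amine or a carboxylic acid in place of that fluorine would stay with compound 3 or return to compound 1, and how a longer chain in place of isopropyl would read.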